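Swapping bromo for fluoro on compound 1

The source may hold more compounds than are shown below. What is called first, only, known or untested is meant among the compounds shown, and "the series" means these compounds.

Measured compounds:
- compound 1, `Brc1ccccc1COc1nc2ccccc2s1`: 51.9%
- compound 2, `Brc1ccc(OCCOc2nc3ccccc3s2)c(Br)c1`: 68.6%
- compound 3, `Brc1ccc(OCCOc2nc3ccccc3s2)cc1`: 68.6%

In a functional assay on the whole organism with Mus musculus as the target, in the writhing test, at a dose of 100 mg/kg by the intraperitoneal route (on this read-out lower numbers stand for less inhibition and higher numbers for more inhibition at the one dose given (going by the name of the read-out)), compound 1 gives 51.9%, the lowest of the three numbers, with compound 2 and compound 3 both standing higher by a margin beyond the scatter. For the measured compounds named here, the one measured step, no change at the digits printed from compound 2 to compound 3 (within the scatter), shows that removing a bromo group from an aromatic carbon left the read-out unchanged.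

Compound 4, `Fc1ccccc1COc1nc2ccccc2s1`, has not been measured. It differs from compound 1 by fluoro in place of bromo on an aromatic carbon. Going by the values given here, no measured step exchanges one halogen for another on the shared core, so the nearest guide is the step from compound 2 to compound 3, where taking a bromo away made no difference beyond the scatter. The step from compound 1 to compound 4 is therefore expected to be small, a number 1.9 percentage points lower from compound 1 to compound 4 (within the scatter), with no clear direction. Compound 4 is estimated to give 50%, within a range from 35% to 65%.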

Compound 4, a percentage reported as inhibition, in the whole organism at one dose (the size of the read-out at that dose, not a potency): 51.9%
For compound 4 the middle estimate is 1.9 percentage points below the measured one; low and high end bracket the measured number.
By their numbers in this assay, from the lowest: compounds 1 and 4 (each within the scatter of the next); then compounds 2 and 3 (each within the scatter of the next).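

In this assay, on an aromatic carbon ortho to a large group, fluoro can stand in place of bromo, with no change at the digits printed from compound 1 to compound 4 (within the scatter). For the compounds shown here, the earlier step, no change at the digits printed from compound 2 to compound 3 (within the scatter), showed only that a bromo could be taken away from another compound; this is the first exchange of one halogen for another on a shared core, and at this position the read-out does not separate the two halogens. Nothing measured here explains why the two halogens give the same read-out.

From the compounds shown here alone, what stays open is whether this position needs a halogen at all, which hydrogen in the same place on compound 1 would help to settle. Going by these compounds, it is also open how a larger or differently built group, such as methoxy, an amine or a carboxylic acid, would fare there.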